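Aryl sulfonate series: methoxy to fluoro on the ester phenyl

The compounds below may be only part of what the source reports. "The series", "measured", "known", "first", "only" and "open" are said of these compounds alone.

Compound 1 `COc1cccc(OS(=O)(=O)c2ccc(N3CCN(C)C3=O)cc2)c1` is the reference of the set. In a functional assay on HT-29 cells (Homo sapiens) for antiproliferative activity, read by sulforhodamine B assay, with a stated time of 48 h (on this read-out higher numbers stand for weaker inhibition and lower numbers for stronger inhibition), compound 1 gives 2500 nM. Compound 2 `CN1CCN(c2ccc(S(=O)(=O)Oc3cccc(F)c3)cc2)C1=O` carries the change (fluoro in place of methoxy on an aromatic carbon). In this assay compound 2 reaches only the limit of the assay, > 100000 nM. The step of an at least 40-fold higher number from compound 1 to compound 2 (1.60 log units; beyond the scatter) therefore marks a loss of inhibition. Compound 3 `COc1ccc(OS(=O)(=O)c2ccc(N3CCN(C)C3=O)cc2)cc1` differs from compound 1 by 4-methoxyphenyl in place of 3-methoxyphenyl on an oxygen. In this assay compound 3 likewise gives a limit, > 100000 nM. The step of an at least 40-fold higher number from compound 1 to compound 3 (1.60 log units; beyond the scatter) is also a loss. Between compound 2 and compound 3 the step that the two limits leave unreadable from compound 2 to compound 3 cannot be read, since both stand at a limit. A point to keep in view is the limit of > 100000 nM in this assay, at which 2 of the 3 values shown sit.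

Compound 4 `CN1CCN(c2ccc(S(=O)(=O)Oc3ccc(F)cc3)cc2)C1=O` has not been measured in this assay. It differs from compound 3 by fluoro in place of methoxy on an aromatic carbon. Going by the values given here, this is the same kind of change as the one from compound 1 to compound 2, but the place is not the same: there the fluoro sits meta to a large group, here para to a large group. The earlier step, an at least 40-fold higher number from compound 1 to compound 2 (1.60 log units; beyond the scatter), was a large rise in the number. The expected step is a step that the limit leaves unreadable from compound 3 to compound 4, with the starting point already a limit. Compound 4 is expected to give 150000 nM, between 30000 nM and 600000 nM, most likely again reported as a limit.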

Compound 4, half-maximal inhibitory concentration: > 100000 nM
Compound 4 gave a limit, no number (the forecaster's own chance of this, stated with the estimate: 85%); the middle value lies beyond the limit too.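

In this assay compound 4 gives > 100000 nM, which is a limit of the assay and not a number. Going by these compounds alone, the steps to compound 4 from compound 2 and from compound 3 cannot be read, as both ends of each pair stand at a limit: the limit of > 100000 nM in this assay, at which 3 of the 4 values shown sit. The one readable new step, an at least 40-fold higher number from compound 1 to compound 4 (1.60 log units; beyond the scatter), is a large loss of inhibition, but it combines fluoro in place of methoxy with a different place on the ring, and it does not isolate either change; the series thus shows that the 4-fluorophenyl compound stays at the limit, not that the change from methoxy to fluoro has the same effect in both places, as the starting compound 3 leaves no room to see any further loss.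

Still open, going by these compounds, is whether compound 2, compound 3 and compound 4 differ at all at concentrations beyond the limit, as only compound 1 gives a number here. Also open, on these data alone, is whether a phenyl ester carrying an amine, a carboxylic acid or a longer alkoxy chain in place of methoxy would give a measurable value in this assay.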